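The source may report more compounds than this note shows. Statements on the series, on what has been measured and on what is new or still open speak of the compounds shown alone.

Going by the values given here, in a functional assay on U-251 cells (Homo sapiens) (on this read-out lower numbers stand for stronger inhibition of growth and higher numbers for weaker inhibition of growth), compound 2 `O=S(=O)(/C=C/c1ccc(Cl)c(Cl)c1)Cc1ccc(Nc2ncnc3ccccc23)cc1` gives 11000 nM as the lowest of the actual numbers so far. Compound 3 `CC(C)(C)c1cc(/C=C/S(=O)(=O)Cc2ccc(Nc3ncnc4ccccc34)cc2)cc(C(C)(C)C)c1O` stands higher at 38000 nM and so inhibits growth less. Compound 1 `N#Cc1ccc(/C=C/S(=O)(=O)Cc2ccc(Nc3ncnc4ccccc34)cc2)cc1` reads > 100000 nM which is a limit and not a number. Compound 4 `O=S(=O)(/C=C/c1ccc(Cl)cc1)Cc1ccc(Nc2ncnc3ccccc23)cc1` alters compound 2 in one place: hydrogen in place of chloro on an aromatic carbon and in words this is hydrogen in place of chloro on an aromatic carbon. Among the compounds with values here, the one measured step that bears on this is an at least 9.0-fold lower number from compound 1 to compound 2 (0.95 log units; beyond the scatter) from 4-cyanophenyl to 3,4-dichlorophenyl. Compound 4 keeps one chloro, so a modest rise is expected in this assay towards weaker inhibition of growth. The expected size is a 2.3-fold higher number from compound 2 to compound 4 (0.36 log units; beyond the scatter) for this change. Compound 4 is estimated at 25000 nM with an expected range of 9000 nM to 75000 nM in this estimate.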

Compound 4, concentration for 50% growth inhibition: 49000 nM
For compound 4 the middle estimate is 2.0-fold (0.29 log units) below the measured one; measured number inside the range.
By their numbers in this assay, from the lowest: compound 2; then compounds 3 and 4 (each within the scatter of the next). At a limit, above all of these: compound 1.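

In this assay, putting hydrogen in place of the chloro that sits ortho to a chloro group gives a 4.5-fold higher number from compound 2 to compound 4 (0.65 log units; beyond the scatter), so growth inhibition weakens. The earlier step swapped 4-cyanophenyl for 3,4-dichlorophenyl and could not show what this one chloro adds alone; compound 4 isolates it. Compound 1 reads > 100000 nM, which is a limit and not a number. Chloro in place of cyano on an aromatic carbon gives an at least 2.0-fold lower number from compound 1 to compound 4 (0.30 log units; that floor lies within the scatter), so this step does not settle how far apart the two compounds lie.

From the compounds shown here alone, whether a group other than chloro, such as a methyl or an amine, would work at this position stays open. So does whether this chloro would help without the other chloro, as in 3-chlorophenyl.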